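The source may report more compounds than this note shows. Statements on the series, on what has been measured and on what is new or still open speak of the compounds shown alone.

Working notes on the series.

Compound 1 `FC(F)(F)c1ccc(/C=C\c2cc3ccccc3nc2Cl)cc1` and compound 2 `COc1ccc2nc(Cl)c(/C=C\c3ccc(C(F)(F)F)cc3)cc2c1` differ by methoxy in place of hydrogen on an aromatic carbon. In a functional assay on MCF7 cells (Homo sapiens) for antiproliferative activity, read by sulforhodamine B assay, with a stated time of 72 h (on this read-out higher numbers stand for weaker inhibition and lower numbers for stronger inhibition), compound 1 gives 4260 nM, and compound 2 gives 12400 nM; the step is a 2.9-fold higher number from compound 1 to compound 2 (0.46 log units; beyond the scatter). Compound 3 `FC(F)(F)c1cccc(/C=C\c2cc3ccccc3nc2Cl)c1` has the same atoms as compound 1 joined differently; how the two cores differ is not broken down here. In this assay compound 3 gives 3530 nM, within the scatter of compound 1 and beyond it relative to compound 2.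

Compound 4 `COc1ccc2nc(Cl)c(/C=C\c3cccc(C(F)(F)F)c3)cc2c1` differs from compound 3 by methoxy in place of hydrogen on an aromatic carbon, the same change that carries compound 1 to compound 2, at the same place. Among the compounds with values here, it is expected to move compound 4 by a 2.8-fold higher number from compound 3 to compound 4 (0.45 log units; beyond the scatter) in this assay, resting on the single earlier step of a 2.9-fold higher number from compound 1 to compound 2 (0.46 log units; beyond the scatter). Compound 4 is therefore estimated at 10000 nM, within 5000 nM to 22000 nM.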

Compound 4, half-maximal inhibitory concentration: 2780 nM
Beside the measured number, compound 4's estimate is 3.6-fold (0.56 log units) above it; the measured number lies below the stated range.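

In this assay, methoxy in place of hydrogen on an aromatic carbon gives a 1.3-fold lower number from compound 3 to compound 4 (0.10 log units; within the scatter), so the step seen on the core of compound 1 does not carry over to the core of compound 3: the same change on two cores in this assay, a 2.9-fold higher number (0.46 log units; beyond the scatter) from compound 1 to compound 2 and a 1.3-fold lower number (0.10 log units; within the scatter) from compound 3 to compound 4, 3.7-fold (0.57 log units) apart, beyond the scatter of two such steps. For these two pairs, then, the size of the methoxy step depends on the core, and a step read on one core is a poor guide to the other. This does not show why the two steps part, and two pairs give no rule for any other core in the series.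

On these data alone, whether an amine or a nitrile on that same aromatic carbon would also depend on the core stays open. So does whether a longer alkoxy chain would separate the two cores in the same way.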